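The source may hold more compounds than are shown below. What is called first, only, known or untested is meant among the compounds shown, and "the series" means these compounds.

In an ADME assay (Homo sapiens) for cytotoxicity (on this read-out lower numbers stand for higher toxicity in this test and higher numbers for lower toxicity in this test), compound 3 `CC(=O)N1CCC(C(=O)N(CCCN2CCN(Cc3ccccc3)CC2)c2ccc(C)c(Cl)c2)CC1` gives 101000 nM, the highest of the two plain numbers shown. Compound 2 `CC(=O)N1CCC(C(=O)N(CCCN2CCC(CNc3cc(C)ccn3)CC2)c2ccc(C)c(Cl)c2)CC1` gives 17900 nM in this assay, a clearly lower number. Compound 1 `CC(=O)N1CCC(C(=O)N(CCCN2CCC(CNC(=O)c3cnccn3)CC2)c2ccc(C)c(Cl)c2)CC1` gives > 52400 nM in this assay, and this is a limit of the assay rather than a number (the limit of > 52400 nM in this assay, at which 1 of the 3 values shown sits). Among the compounds with values here, the single measured step, an at least 2.9-fold lower number from compound 1 to compound 2 (0.46 log units; beyond the scatter), changes a different part of the shared core. Compound 4 `CC(=O)N1CCC(C(=O)N(CCCN2CCN(Cc3ccc(Cl)nc3)CC2)c2ccc(C)c(Cl)c2)CC1` differs from compound 3 in one place: 6-chloropyridin-3-yl in place of phenyl on a saturated chain carbon bound to an amine nitrogen in a ring. Within the data shown here, no measured step covers this exchange of a phenyl for a 6-chloropyridin-3-yl, so no change beyond the scatter is expected in this assay, with a 1.0-fold lower number from compound 3 to compound 4 (0.00 log units; within the scatter) as the expected step. Compound 4 is therefore estimated at 100000 nM, between 40000 nM and 250000 nM.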

Compound 4, half-maximal cytotoxic concentration: > 53100 nM
Compound 4: no number, only a limit; the forecaster's own chance of this, stated with the estimate: 25%; the middle value does not contradict the limit.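

Within the data shown here, compound 4 gives > 53100 nM, which is a limit of the assay and not a number, so no step from compound 3 to compound 4 can be read. The compounds shown leave open whether 6-chloropyridin-3-yl in place of phenyl changes this read-out at all.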